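From Cyano to Bromo on the Sulfonyl Aryl Group

The source may hold more compounds than are shown below. What is called first, only, known or untested is meant among the compounds shown, and "the series" means these compounds.

The shared core is carried by compound 1 `COC(=O)c1cc(=O)c2c(OC)cc(OC)cc2n1S(=O)(=O)c1ccc(C)cc1`, compound 2 `COc1ccc(-c2cc(=O)c3c(OC)cc(OC)cc3n2S(=O)(=O)c2ccc([N+](=O)[O-])cc2)cc1` and compound 3 `COc1ccc(-c2cc(=O)c3c(OC)cc(OC)cc3n2S(=O)(=O)c2ccc(C#N)cc2)cc1`. In a functional assay on HepG2 cells (Homo sapiens) for antiproliferative activity, with a stated time of 72 h (a higher number here means that more compound is needed for the effect, a lower number that less compound is needed), compound 1 gives only a limit, > 20000 nM. Compound 2 likewise gives only a limit, > 29300 nM. Compound 3 also gives only a limit, > 17200 nM, so all three values sit at limits and compound 3 cannot be placed above or below the others. The step that the two limits leave unreadable from compound 2 to compound 3 is unreadable for the same reason. Compound 4 `COc1ccc(-c2cc(=O)c3c(OC)cc(OC)cc3n2S(=O)(=O)c2ccc(Br)cc2)cc1` differs from compound 3 by bromo in place of cyano on an aromatic carbon. Among the compounds with values here, only the step from compound 2 to compound 3 bears on the same place, and it gives no size, so the expected step that the limit leaves unreadable from compound 3 to compound 4 rests on little. Compound 4 is estimated at 25000 nM, between 8000 nM and 80000 nM, most likely again reported as a limit.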

Compound 4, half-maximal effective concentration: 16300 nM
Compound 4: the middle estimate sits 1.5-fold (0.19 log units) above what was measured; the range from low to high includes it.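

Within the data shown here, with bromo on this aromatic carbon, compound 4 gives the only value of the four in this assay that is not a limit, so the change from cyano now has a floor: an at least 1.0-fold lower number from compound 3 to compound 4 (0.02 log units; that floor lies within the scatter). Bromo in place of nitro reads as an at least 1.7-fold lower number from compound 2 to compound 4 (0.25 log units; that floor lies within the scatter). Neither floor shows a difference beyond the scatter, and the step from compound 2 to compound 3 still cannot be read.

From the compounds shown here alone, the true size of both steps stays open, since compound 2 and compound 3 are known only by limits. Also open, going by these compounds, is whether an amine or a carboxylic acid on this aromatic carbon would give a clearly lower number.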